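Replacing the bicyclic group of compound 2 with a single ring

A few compounds are considered here, and "the series" means these few. Any claim that something is new, unique, unknown or untested is made for them only; others in the source may bear on it.

Two compounds of the series carry numbers in a functional assay for inhibition of Thromboxane-A synthase (Homo sapiens); a lower number here means a stronger inhibitor, a higher number a weaker inhibitor. Compound 1 `CCCOC(=O)c1ccc(COC(COCc2ccc(OC)cc2)Cn2ccnc2)cc1` gives 180 nM. Compound 2 `COc1ccc(COCC(Cn2ccnc2)OCc2ccc3c(c2)COC3=O)cc1` gives 6200 nM, the higher of the two numbers; the gap to compound 1 lies beyond the scatter, so compound 2 is the weaker inhibitor of the pair. Both share the same core and differ in the group carried on the saturated chain carbon bound to an oxygen on a saturated carbon.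

Going by the values given here, compound 3 `COc1ccc(COCC(Cn2ccnc2)OCc2ccc([S+](C)[O-])cc2)cc1` keeps that core and changes only this group: a group of 9 heavy atoms (7 carbon, 1 oxygen, 1 sulfur; one six-membered aromatic ring of carbon only) in place of a group of 10 heavy atoms (8 carbon, 2 oxygen; one five-membered non-aromatic ring with 1 hetero atom, one six-membered aromatic ring of carbon only), on a saturated chain carbon bound to an oxygen on a saturated carbon. Among the compounds with values here, no measured pair isolates this change, so nothing fixes its size directly. What the numbers of compound 1 and compound 2 do show is that the group at this position moves the read-out strongly, and that a group built on one six-membered aromatic ring of carbon only went with the lower number. On that basis the step is expected toward a lower number, estimated as a 4.1-fold lower number from compound 2 to compound 3 (0.62 log units; beyond the scatter), beyond the scatter. The half-maximal inhibitory concentration of compound 3 is thus expected at 1500 nM, with a range of 300 nM to 8000 nM.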

Compound 3, half-maximal inhibitory concentration: 8600 nM
For compound 3 the middle estimate is 5.7-fold (0.76 log units) below the measured one; measured number outside the range, above it.
By their numbers in this assay, from the lowest: compound 1; then compounds 2 and 3 (each within the scatter of the next).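

In this assay, exchanging the group of 10 heavy atoms for the group of 9 heavy atoms on the saturated chain carbon gives a 1.4-fold higher number from compound 2 to compound 3 (0.14 log units; within the scatter), so a single six-membered aromatic ring of carbon only does not by itself go with the lower number in this series. With that ring kept, changing only the group on an aromatic carbon gives a 48-fold higher number from compound 1 to compound 3 (1.68 log units; beyond the scatter), which places the large difference among these three compounds in the group on that aromatic carbon. No measurement shown here accounts for this difference.

Still open, going by these compounds, is which part of the group on that aromatic carbon in compound 1 goes with its lower number. A carboxylic acid, a methyl ester or an amide on the same aromatic carbon would help to separate the contribution of the carbonyl from that of the chain.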